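The source may report more compounds than this note shows. Statements on the series, on what has been measured and on what is new or still open speak of the compounds shown alone.

Working notes on the hydrazone series.

Compound 1 `C(=N/Nc1nc2ccccc2nc1Cc1ccccc1)\c1ccccc1` carries an unsubstituted phenyl on the carbon double-bonded to nitrogen and in an assay on isolated protein for inhibition of Amine oxidase [flavin-containing] A (Homo sapiens), read by spectrophotometry (on this read-out higher numbers stand for weaker inhibition and lower numbers for stronger inhibition), compound 1 gives 81 nM. Compound 2 `Clc1ccccc1/C=N/Nc1nc2ccccc2nc1Cc1ccccc1` gives 5.8 nM in this assay, and compound 3 `O=[N+]([O-])c1ccc(/C=N/Nc2nc3ccccc3nc2Cc2ccccc2)cc1` gives 8.8 nM. Compound 3 therefore holds the second highest of the three numbers; its nearest neighbour is compound 2, and the step of a 1.5-fold higher number from compound 2 to compound 3 (0.18 log units; within the scatter) stays within the scatter, so the two cannot be ordered. Its furthest neighbour is compound 1, from which the step of a 9.2-fold lower number from compound 1 to compound 3 (0.96 log units; beyond the scatter) is beyond the scatter.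

The next compound, compound 4 `Brc1cccc(/C=N/Nc2nc3ccccc3nc2Cc2ccccc2)c1`, differs from compound 3 by one change: 3-bromophenyl in place of 4-nitrophenyl on a carbon with a double bond to nitrogen. Among the measured compounds shown here, two measured steps bear on this. Putting a halogen on the aryl ring, as in a 14-fold lower number from compound 1 to compound 2 (1.15 log units; beyond the scatter), gave a large fall in number; putting the nitro group there, as in a 9.2-fold lower number from compound 1 to compound 3 (0.96 log units; beyond the scatter), gave a modest one, and the two substituted aryls sit within the scatter of each other. For the measured compounds named here, a bromine at a different position of the ring has no direct precedent here, so the expected step from compound 3 is a 1.4-fold higher number from compound 3 to compound 4 (0.13 log units; within the scatter), close to no change beyond the scatter. Compound 4 is accordingly estimated at 12 nM, with a range from 4 nM to 40 nM.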

Compound 4, half-maximal inhibitory concentration: 9.8 nM
Estimate against measurement, compound 4: 1.2-fold (0.09 log units) above, and the stated range covers the measured number.
By their numbers in this assay, from the lowest: compounds 2, 3 and 4 (each within the scatter of the next); then compound 1.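

With 3-bromophenyl in place of 4-nitrophenyl on the carbon with a double bond to nitrogen, the hydrogen-bond acceptors counted on the leaving group are gone, yet this assay shows no change beyond the scatter (a 1.1-fold higher number from compound 3 to compound 4 (0.05 log units; within the scatter)), and the comparison with the 2-chlorophenyl compound also stays within the scatter (a 1.7-fold higher number from compound 2 to compound 4 (0.23 log units; within the scatter)). Compounds 2, 3 and 4 therefore cannot be ordered, although they differ in substituent and in its printed place on the ring, while bromo in place of hydrogen still separates clearly from the unsubstituted phenyl (an 8.3-fold lower number from compound 1 to compound 4 (0.92 log units; beyond the scatter)), so all three substituted compounds shown lie beyond the scatter of compound 1, with none going against this. Nothing available gives a reason for these steps.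

The compounds shown do not separate the identity of the substituent from its place on the ring, since no single group appears at more than one place. Going by these compounds, it also remains open whether this flat response extends to an amine, a carboxylic acid or a methoxy group on the ring, or whether such groups would fall back towards compound 1 or move beyond the scatter of compounds 2, 3 and 4.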